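Terminal aryl substituent exchange on the shared core: working notes

The source may report more compounds than this note shows. Statements on the series, on what has been measured and on what is new or still open speak of the compounds shown alone.

Measured so far in a functional assay on A549 cells (Homo sapiens) for antiproliferative activity, read by MTT assay, with a stated time of 48 h; a higher number here means a weaker inhibitor, a lower number a stronger inhibitor:
compound 1 `CCCCCCOc1ccc(C(=O)/C=C/c2c(/C=C/c3ccc(OC)cc3)cc(OC)cc2OC)cc1`: 8.4 ug/mL
compound 2 `COc1ccc(/C=C/c2cc(OC)cc(OC)c2/C=C/C(=O)c2ccc(F)cc2)cc1`: 6.6 ug/mL
compound 3 `COc1ccc(/C=C/c2cc(OC)cc(OC)c2/C=C/C(=O)c2ccc(OC)cc2)cc1`: 4.5 ug/mL

Compound 1 gives the highest of the three numbers, but every step from it stays within the scatter: a 1.3-fold lower number from compound 1 to compound 2 (0.10 log units; within the scatter) and a 1.9-fold lower number from compound 1 to compound 3 (0.27 log units; within the scatter); the remaining pair shows a 1.5-fold lower number from compound 2 to compound 3 (0.17 log units; within the scatter). Compound 4 `COc1ccc(/C=C/c2cc(OC)cc(OC)c2/C=C/C(=O)c2ccc(-c3ccccc3)cc2)cc1` differs from compound 1 by phenyl in place of hexyloxy on an aromatic carbon. Among the compounds with values here, no measured step exchanges hexyloxy for phenyl, so the only bearings are the other exchanges on the same aromatic carbon, a 1.3-fold lower number from compound 1 to compound 2 (0.10 log units; within the scatter) and a 1.9-fold lower number from compound 1 to compound 3 (0.27 log units; within the scatter), both small. The step of a 1.2-fold lower number from compound 1 to compound 4 (0.08 log units; within the scatter) is therefore expected to stay within the scatter, with no clear direction. Compound 4 is estimated at 7 ug/mL, with a range of 3.5 ug/mL to 14 ug/mL.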

Compound 4, half-maximal inhibitory concentration: 4.6 ug/mL
Beside the measured number, compound 4's estimate is 1.5-fold (0.18 log units) above it, within the range that was stated.
By their numbers in this assay, from the lowest: compounds 3, 4, 2 and 1 (each within the scatter of the next).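

Phenyl, which brings a six-membered aromatic ring to this aromatic carbon, stays within the scatter of all three earlier groups (a 1.8-fold lower number from compound 1 to compound 4 (0.26 log units; within the scatter); a 1.4-fold lower number from compound 2 to compound 4 (0.16 log units; within the scatter); a 1.0-fold higher number from compound 3 to compound 4 (0.01 log units; within the scatter)). Hexyloxy, fluoro, methoxy and phenyl therefore allow no ordering at this position, although the exchange now spans both a chain and a ring. No measurement shown here accounts for this result.

As far as these compounds go, whether an amine, a carboxylic acid or a longer chain on the same aromatic carbon would give a step beyond the scatter remains open. From the compounds shown here alone, whether the same flat result holds on a different core also remains open.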